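Acyl-urea thiazole hydrazones: positional change of ring fluorines

This account rests on a few compounds, and the source may have more. Where it says the series, first, only, none or still open, it means among the compounds named here.

Measured so far in a functional assay on HepG2 cells (Homo sapiens) for inhibition, read by MTT assay, with a stated time of 72 h; a lower number here means a stronger inhibitor, a higher number a weaker inhibitor:
compound 1 `CN(C(=O)NC(=O)c1ccc(Cl)cc1Cl)c1nc(C(F)(F)F)c(C(=O)N/N=C/c2ccc(C(F)(F)F)cc2)s1` — 12.4 ug/mL
compound 2 `CN(C(=O)NC(=O)c1ccc(F)c(F)c1)c1nc(C(F)(F)F)c(C(=O)N/N=C/c2cc(C(F)(F)F)cc(C(F)(F)F)c2)s1` — 5.47 ug/mL
compound 3 `CN(C(=O)NC(=O)c1ccc(F)c(F)c1)c1nc(C(F)(F)F)c(C(=O)N/N=C/c2cccc(C(F)(F)F)c2)s1` — 5.6 ug/mL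

Compound 2 holds the lowest number of the three, but its gap to compound 3 is within the scatter, so the two cannot be ordered; the change of hydrogen in place of trifluoromethyl on an aromatic carbon gave a 1.0-fold higher number from compound 2 to compound 3 (0.01 log units; within the scatter). Compound 1, which differs from compound 2 in two places, stands apart with a higher number beyond the scatter; no single step links it to the others, so only the two values are shown.

Compound 4 `CN(C(=O)NC(=O)c1c(F)cccc1F)c1nc(C(F)(F)F)c(C(=O)N/N=C/c2cc(C(F)(F)F)cc(C(F)(F)F)c2)s1` is the next member to be tested in this assay. The change from compound 2 is 2,6-difluorophenyl in place of 3,4-difluorophenyl on a carbonyl carbon, leaving everything else untouched. Going by the values given here, none of the measured steps moves fluorines around the same ring: the only recorded step concerns the trifluoromethyl on the other aromatic ring and was flat. There is therefore no measured basis for a shift in either direction, and the working expectation is a step near zero or a modest weakening.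

Compound 4 is accordingly expected to give about 8 ug/mL in this assay, with a range from 3 ug/mL to 22 ug/mL. That corresponds to an expected step of a 1.5-fold higher number from compound 2 to compound 4 (0.17 log units; within the scatter).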

Compound 4, half-maximal inhibitory concentration: 6.28 ug/mL
For compound 4 the middle estimate is 1.3-fold (0.11 log units) above the measured one; the measured number falls inside the stated range.
By their numbers in this assay, from the lowest: compounds 2, 3, 4 and 1 (each within the scatter of the next, the first and the last beyond it).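

In this assay, going by these compounds alone, the step from 3,4-difluorophenyl to 2,6-difluorophenyl on a carbonyl carbon is the only recorded step at this position, and with the atom count unchanged it gives a 1.1-fold higher number from compound 2 to compound 4 (0.06 log units; within the scatter) and so no readable difference between the two fluorine patterns. With this result, compound 2 now has one recorded step on each aromatic ring, the other being a 1.0-fold higher number from compound 2 to compound 3 (0.01 log units; within the scatter), and both lie within the scatter, so neither change separates its pair of compounds in this assay. No separate measurement accompanies these values that could account for them.

On these data alone, whether this position tolerates more than a rearrangement of two fluorines remains open: a phenyl carrying methoxy, an amine or a carboxylic acid on this carbonyl carbon would test whether the step stays within the scatter. Also open, as far as these compounds go, is whether the 2,6-difluorophenyl group gives the same reading when paired with other aryl groups on the hydrazone, such as a pyridine ring or a phenyl carrying a nitrile.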